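The source may hold more compounds than are shown below. What is called first, only, known or untested is meant among the compounds shown, and "the series" means these compounds.

Compound 1 `O[C@@H](COc1ccc(F)cc1)CN1CCN(c2ccc(F)cc2)CC1` is measured in an assay on HEK293 cells for inhibition of Voltage-dependent T-type calcium channel subunit alpha-1G (Homo sapiens), read by patch clamp, tested at 10 uM (a lower number here means less inhibition, a higher number more inhibition at the concentration tested (going by the name of the read-out)), where compound 1 gives 47.5%. Two close relatives have been measured alongside it. Compound 2 `O[C@@H](COc1ccc(C(F)(F)F)cc1)CN1CCN(c2ccc(F)cc2)CC1` gives 53.7% in this assay, and compound 3 `COc1ccccc1N1CCN(C[C@@H](O)COc2ccc(F)cc2)CC1` gives 50.7%. Among these three numbers compound 1 sits lowest, yet the gaps are small: a number 6.2 percentage points higher from compound 1 to compound 2 (within the scatter), and a number 3.2 percentage points higher from compound 1 to compound 3 (within the scatter). Neither change moved the read-out beyond the scatter.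

Compound 4 `O[C@H](COc1ccc(F)cc1)CN1CCN(c2ccc(F)cc2)CC1` has not yet been measured. Its relation to compound 1 is this: the two compounds have the same atoms and bonds and differ only in configuration as drawn: 1 of 1 stereo elements differ; a stereocentre at a saturated chain carbon is drawn R in compound 1 and S in compound 4. Neither measured step bears on such a change: the step from compound 1 to compound 2 exchanged one group on a ring for another, and the step from compound 1 to compound 3 exchanged the group on the ring nitrogen, and both kept the configuration as drawn fixed. There is thus no measured guide for how the read-out responds to the mirror arrangement at this carbon, and either direction is possible. With no such evidence, the expected step is a number 5.5 percentage points lower from compound 1 to compound 4 (within the scatter), carrying a wide range. Compound 4 is estimated to give 42% in this assay, between 20% and 62%.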

Compound 4, a percentage reported as inhibition, at one concentration (the size of the read-out at that concentration, not a potency): 50%
For compound 4 the middle estimate is 8 percentage points below the measured one; the measured number falls inside the stated range.
By their numbers in this assay, from the lowest: compounds 1, 4, 3 and 2 (each within the scatter of the next).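

Turning the stereocentre at the saturated chain carbon from R to S gives a number 2.5 percentage points higher from compound 1 to compound 4 (within the scatter) in this assay. For the compounds shown here, the earlier steps changed groups and kept this carbon as drawn, so this pair is the first to test configuration on its own: the fact that compounds 1 and 4 differ only in the configuration as drawn At the single concentration tested, the read-out therefore does not separate the two mirror forms, although a percentage at one concentration is not a potency and cannot rule out a difference that shows up at other concentrations.

As far as these compounds go, whether the mirror arrangement would make as little difference with the trifluoromethyl group of compound 2 or the 2-methoxyphenyl group of compound 3 remains open. So does the response of the read-out if the hydroxyl gave way to a carboxylic acid.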